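Methoxy for Methyl on a Series Held at the Limit

The source may hold more compounds than are shown below. What is called first, only, known or untested is meant among the compounds shown, and "the series" means these compounds.

Two close relatives share one core and differ only on the pendant six-membered ring. Compound 1 `CNC(=O)c1c(NO)cc(-c2ccccc2)oc1=O` carries a bare ring, and compound 2 `CNC(=O)c1c(NO)cc(-c2ccc(C)cc2)oc1=O` carries a methyl on an aromatic carbon of that ring. In an ADME assay on Huh-7 cells (Homo sapiens) for cytotoxicity, read by a luciferase reporter and WST assay, with a stated time of 3 days (on this read-out higher numbers stand for lower toxicity in this test and lower numbers for higher toxicity in this test), compound 1 gives > 20000 nM, which is a limit of the test rather than a number. In this assay compound 2 gives > 20000 nM, again a limit and not a number. The step that the two limits leave unreadable from compound 1 to compound 2 cannot be read for that reason. Compound 2 thus stands at the limit of the test, together with every other value shown, as the limit of > 20000 nM in this assay, at which 2 of the 2 values shown sit, records.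

Compound 3 `CNC(=O)c1c(NO)cc(-c2ccc(OC)cc2)oc1=O` is the next member and is not yet measured. It differs from compound 2 by methoxy in place of methyl on an aromatic carbon. Among the compounds with values here, the only measured step bears on this change solely in that it left both compounds at the limit, so neither a direction nor a size can be drawn from it. Compound 3 is therefore expected to sit at the same limit, with a step that the limit leaves unreadable from compound 2 to compound 3 expected to be none beyond the scatter. The estimate for compound 3 in this assay is 30000 nM, within 15000 nM to 100000 nM.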

Compound 3, half-maximal cytotoxic concentration: > 20000 nM
Compound 3: only a limit was reported; the forecaster's own chance of this, stated with the estimate: 85%; the middle value does not contradict the limit.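

In this assay compound 3 gives > 20000 nM as a limit of the test, not a number. Within the data shown here, no step among compound 1, compound 2 and compound 3 can be read, because all three stand at one shared limit: the limit of > 20000 nM in this assay, at which 3 of the 3 values shown sit. The compounds shown leave open whether methyl or methoxy on the ring changes toxicity at all, and at what concentration any of the three would harm the cells.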